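From a trimethylpyrrole amide to an isobutyl carbamate

The source may hold more compounds than are shown below. What is called first, only, known or untested is meant among the compounds shown, and "the series" means these compounds.

The shared core appears in compound 1 `Cc1ccccc1C(=O)Nc1ccc2nc(NC(=O)C3CCCCC3)sc2c1`, which in a functional assay on WI-38 VA13 cells (Homo sapiens) for cytotoxicity (a lower number here means that less compound is needed, a higher number that more compound is needed for the effect), gives 0.085 ug/mL. Compound 2 `O=C(Nc1ccc2nc(NC(=O)C3CCCCC3)sc2c1)c1c(Cl)cccc1Cl` gives 0.015 ug/mL in this assay, a step of a 5.7-fold lower number from compound 1 to compound 2 (0.75 log units; beyond the scatter). Compound 3 `Cc1cc(C(=O)Nc2ccc3nc(NC(=O)C4CCCCC4)sc3c2)c(C)n1C` reached only a limit of the assay in this assay, namely > 6.2 ug/mL. Going by the values given here, compound 3 is the one value among the three that sits at this limit (the limit of > 6.2 ug/mL in this assay, at which 1 of the 3 values shown sits), so its true position is known only as a bound. Both measured steps into compound 3 were large: an at least 72-fold higher number from compound 1 to compound 3 (1.86 log units; beyond the scatter) and an at least 410-fold higher number from compound 2 to compound 3 (2.61 log units; beyond the scatter). Compound 4 `CC(C)COC(=O)Nc1ccc2nc(NC(=O)C3CCCCC3)sc2c1` differs from compound 3 by isobutoxy in place of 1,2,5-trimethyl-1H-pyrrol-3-yl on a carbonyl carbon. Among the compounds with values here, no measured step exchanges a ring for an open chain on this carbonyl carbon, so the two steps into compound 3 bear only indirectly; they show that the group leaving was the weakest of the three tried there. Compound 4 is therefore expected to move back toward a lower number, an at least 4.1-fold lower number from compound 3 to compound 4 (0.61 log units; beyond the scatter), though with wide uncertainty. Compound 4 is estimated at 1.5 ug/mL, within a range from 0.1 ug/mL to 10 ug/mL.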

Compound 4, half-maximal effective concentration: 0.72 ug/mL
The estimate for compound 4 lay 2.1-fold (0.32 log units) above the measured number; the measured number falls inside the stated range.
By their numbers in this assay, from the lowest: compound 2; then compound 1; then compound 4. At a limit, above all of these: compound 3.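

In this assay, the carbonyl carbon on the amide-type nitrogen now carries a group with no ring, and isobutoxy brings the number back from the limit, with an at least 8.6-fold lower number from compound 3 to compound 4 (0.93 log units; beyond the scatter). This step is only a bound, since compound 3 sits at a limit of the assay: the limit of > 6.2 ug/mL in this assay, at which 1 of the 4 values shown sits. The open chain still does not match either substituted phenyl group, with an 8.5-fold higher number from compound 1 to compound 4 (0.93 log units; beyond the scatter) and a 48-fold higher number from compound 2 to compound 4 (1.68 log units; beyond the scatter), so the presence of a ring does not by itself set the order, as the ring-bearing compound 3 stands at the limit while compound 1 and compound 2 give the lowest numbers.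

On these data alone, what a methoxy group, a longer alkoxy chain or an amine would give on this carbonyl carbon remains open. The compounds shown also do not separate the contribution of the oxygen in isobutoxy from that of its carbon chain.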